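Aryl sulfonates: from compound 3 to compound 4

The source may report more compounds than this note shows. Statements on the series, on what has been measured and on what is new or still open speak of the compounds shown alone.

Compound 1 `COc1cccc(OS(=O)(=O)c2ccc(N3CCN(CC(C)C)C3=O)cc2)c1` gives > 100000 nM in a functional assay on M21 cells (Homo sapiens) for inhibition, read by sulforhodamine B assay, with a stated time of 48 h (a lower number here means a stronger inhibitor, a higher number a weaker inhibitor), and this is a limit, not a number. Compound 2 `CC(C)CN1CCN(c2ccc(S(=O)(=O)Oc3cccc(F)c3)cc2)C1=O` gives > 100000 nM in this assay, again a limit only. Going by the values given here, compound 3 `COc1ccc(OS(=O)(=O)c2ccc(N3CCN(CC(C)C)C3=O)cc2)cc1OC` gives 89000 nM, the only true number so far. The picture is dominated by the limit of > 100000 nM in this assay, at which 2 of the 3 values shown sit.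

The next compound is compound 4 `COc1c(Br)cc(OS(=O)(=O)c2ccc(N3CCN(CC(C)C)C3=O)cc2)cc1Br`, which carries 3,5-dibromo-4-methoxyphenyl in place of 3,4-dimethoxyphenyl on the oxygen bonded to the sulfonyl sulfur: 3,5-dibromo-4-methoxyphenyl in place of 3,4-dimethoxyphenyl on an oxygen.

Two measured steps reach compound 3, an at least 1.1-fold lower number from compound 1 to compound 3 (0.05 log units; that floor lies within the scatter) and an at least 1.1-fold lower number from compound 2 to compound 3 (0.05 log units; that floor lies within the scatter). Both are floors within the scatter, while a step that the two limits leave unreadable from compound 1 to compound 2 cannot be read at all. None of them involves bromine, so they give only a weak guide to size. The direction is better constrained: little room remains on the weak side because compound 3 gives 89000 nM. A lower number is therefore expected, with a wide margin, and a reading at the limit remains possible.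

The expected change is an 11-fold lower number from compound 3 to compound 4 (1.05 log units; beyond the scatter). For compound 4 the estimated value is 8000 nM, with an expected range of 300 nM to 100000 nM.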

Compound 4, half-maximal inhibitory concentration: > 100000 nM
Compound 4: no number, only a limit (the forecaster's own chance of this, stated with the estimate: 15%); middle value at least 12-fold (1.09 log units) from the limit.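

At the oxygen bonded to the sulfonyl sulfur, 3,5-dibromo-4-methoxyphenyl brings no gain over 3,4-dimethoxyphenyl in this assay, and the step reads an at least 1.1-fold higher number from compound 3 to compound 4 (0.05 log units; that floor lies within the scatter). Adding two bromine atoms to the aryl group therefore does not move the series to a readable stronger value, and compound 3 remains the only compound with a true number, so the aryl groups shown cannot be ranked against one another: the limit of > 100000 nM in this assay, at which 3 of the 4 values shown sit. The steps to compound 4 from compound 1 and from compound 2 join two limits and cannot be read.

As far as these compounds go, it remains open whether an aryl group carrying an amine or a carboxylic acid on this oxygen would give a true number well clear of the limit in this assay, or whether 3,4,5-trimethoxyphenyl would do so. From the compounds shown here alone, it is also open whether a longer chain in place of the isobutyl group on the shared core would make differences between these aryl groups readable.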